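Methyl on the pendant phenyl of the spirocyclic pyrazolone series

This account rests on a few compounds, and the source may have more. Where it says the series, first, only, none or still open, it means among the compounds named here.

Working notes. The series shares a core in which a pyrazolone and a dienone are joined at a spiro carbon, with an aryl on the pyrazolone nitrogen and a second aryl on the dienone. In a functional assay on MDA-MB-231 cells (Homo sapiens) for antiproliferative activity, read by CCK-8 assay, with a stated time of 72 h (on this read-out lower numbers stand for stronger inhibition and higher numbers for weaker inhibition), compound 1 `CC1=NN(c2ccc(Br)cc2)C(=O)C12C=CC(=O)C=C2c1cccc(C)c1` gives 2890 nM. Compound 2 `CC1=NN(c2ccc(C)cc2)C(=O)C12C=CC(=O)C=C2c1ccccc1` carries a methyl in place of the bromine on the first aryl and an unsubstituted phenyl on the dienone; in this assay compound 2 gives 46600 nM, the higher of the two numbers recorded, and the gap to compound 1 lies beyond the scatter. The two compounds differ in two places, so no single step can be read from them.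

Compound 3 `CC1=NN(c2ccc(C)cc2)C(=O)C12C=CC(=O)C=C2c1cccc(C)c1` is the next case: methyl in place of hydrogen on an aromatic carbon. The change reinstates the substituent pattern of the dienone aryl seen in compound 1 while keeping the methyl-bearing aryl of compound 2. Among the measured compounds shown here, with no one-place step measured, the expectation for compound 3 rests on the position of compound 2 at 46600 nM and of compound 1 at 2890 nM only; a step toward the lower number is expected, of moderate size, a 3.1-fold lower number from compound 2 to compound 3 (0.49 log units; beyond the scatter). Compound 3 is accordingly estimated at 15000 nM, with a range from 5000 nM to 40000 nM.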

Compound 3, half-maximal inhibitory concentration: 19400 nM
The estimate for compound 3 lay 1.3-fold (0.11 log units) below the measured number; the measured number falls inside the stated range.
By their numbers in this assay, from the lowest: compound 1; then compound 3; then compound 2.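

In this assay, among the compounds shown here, the change from phenyl to 3-methylphenyl on the second aryl gives a 2.4-fold lower number from compound 2 to compound 3 (0.38 log units; beyond the scatter), the first reading of this position with only one place changed, and the added methyl moves the number toward stronger inhibition. With the 3-methylphenyl held constant, methyl in place of bromo on the first aryl gives a 6.7-fold higher number from compound 1 to compound 3 (0.83 log units; beyond the scatter), so bromo goes with the lower number at that site, and this is the larger of the two steps, both of which lie beyond the scatter. No measurement available here bears on the cause of either step.

The compounds shown leave open whether the methyl step on the second aryl keeps its size when bromo sits on the first aryl, and whether the step depends on the methyl standing on this particular carbon of the ring. Also open, going by these compounds, is how a methoxy group, an amine, a carboxylic acid or a longer chain such as ethyl on that same carbon would read in this assay.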